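Turning Over a Single Stereocentre

A few compounds are considered here, and "the series" means these few. Any claim that something is new, unique, unknown or untested is made for them only; others in the source may bear on it.

In a functional assay on PC-3 cells (Homo sapiens) for antiproliferative activity, read by MTT assay, with a stated time of 72 h (on this read-out lower numbers stand for stronger inhibition and higher numbers for weaker inhibition), compound 1 (`CCn1cc(C(CC)(CC)c2ccc(C#CC(O)(CC)CC)c(C)c2)cc1C(=O)NCC(=O)O`) gives 6300 nM and compound 2 (`CCn1cc(C(CC)(CC)c2ccc(C#CC(O)(CC)CC)c(C)c2)cc1C(=O)N[C@H](C(=O)O)C(C)C`) gives 3750 nM within the scatter of it. Compound 3 (`CCn1cc(C(CC)(CC)c2ccc(C#CC(O)(CC)CC)c(C)c2)cc1C(=O)N[C@@H](C(=O)O)C(C)C`) differs from compound 2 in one way only (the two compounds have the same atoms and bonds and differ only in configuration as drawn: 1 of 1 stereo elements differ; a stereocentre at a saturated chain carbon is drawn S in compound 2 and R in compound 3). Within the data shown here, the one measured step at that carbon (a 1.7-fold lower number from compound 1 to compound 2 (0.23 log units; within the scatter)) brought in the isopropyl, and no measured pair tests configuration. Resting on that small step, the expected size of the change (a 1.1-fold higher number from compound 2 to compound 3 (0.05 log units; within the scatter)) stays inside the scatter, with no firm direction. Compound 3 is estimated at 4200 nM (expected range 1800 nM to 9500 nM).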

Compound 3, half-maximal inhibitory concentration: 10300 nM
For compound 3 the middle estimate is 2.5-fold (0.39 log units) below the measured one, and the stated range ends below it.
By their numbers in this assay, from the lowest: compounds 2, 1 and 3 (each within the scatter of the next, the first and the last beyond it).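

In this assay turning this carbon from S to R brings a 2.7-fold higher number from compound 2 to compound 3 (0.44 log units; beyond the scatter) and so shows that configuration at this position can count, which the earlier pair could not test. That step belongs to this one carbon alone, because nothing else separates the two: the fact that compounds 2 and 3 differ only in the configuration as drawn. Adding the isopropyl in the R form brings a 1.6-fold higher number from compound 1 to compound 3 (0.21 log units; within the scatter) and stays as small as the step with the S form.

Going by these compounds, whether the same S and R gap appears with a longer chain or a benzyl group at this carbon remains open. So does whether it survives replacing the carboxylic acid with a primary amide.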